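Dropping the Carboxy Group from an Arginase Amidine

The compounds below may be only part of what the source reports. "The series", "measured", "known", "first", "only" and "open" are said of these compounds alone.

Of the compounds shown here, two have been measured in an assay for inhibition of arginase-1 (Bos taurus), with a stated time of 30 min, tested at 1 mM; on this read-out lower numbers stand for less inhibition and higher numbers for more inhibition at the one concentration tested (going by the name of the read-out). Compound 1 `COCC(=N)NCCCCN` gives 21% in this assay, while compound 2 `COCCC(=N)NCCC[C@H](N)C(=O)O` gives 43%. Compound 2 therefore holds the higher of the two numbers, standing above compound 1 by a margin beyond the usual scatter.

Compound 3 `COCCC(=N)NCCCCN` has not yet been measured. It differs from compound 2 in one place: hydrogen in place of carboxy on a saturated chain carbon bound to an amine nitrogen and a saturated chain carbon. Among the compounds with values here, compound 2 is the only one of the measured pair that carries a carboxy group, and it is also the one with the higher number in this assay; compound 1, with 21%, stands lower. Within the data shown here, no step between measured compounds isolates this particular change, so its size cannot be read from the data directly.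

The expectation is a downward step of roughly a number 21 percentage points lower from compound 2 to compound 3 (beyond the scatter) in this assay, beyond the scatter. Compound 3 is accordingly estimated to give 22%, with a likely range from 5% to 40%.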

Compound 3, a percentage reported as inhibition, at one concentration (the size of the read-out at that concentration, not a potency): 22%
Compound 3: middle estimate and measured number agree at the digits printed; the range from low to high includes it.
By their numbers in this assay, from the lowest: compounds 1 and 3 (each within the scatter of the next); then compound 2.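

In this assay, within the data shown here, hydrogen in place of carboxy on a saturated chain carbon bound to an amine nitrogen and a saturated chain carbon gives a number 21 percentage points lower from compound 2 to compound 3 (beyond the scatter), the first direct reading of this change, and it shows that the carboxy group at this position makes a difference larger than the usual scatter at the one concentration tested. The second new step concerns the other end of the molecule: methoxymethyl in place of methoxy on a saturated chain carbon bound to a carbon with a double bond to nitrogen gives a number 1 percentage points higher from compound 1 to compound 3 (within the scatter), so in the compounds without the carboxy group, this change leaves the read-out within the scatter. The data offer no measurement that explains either result.

The compounds shown leave open whether a related group at the same carboxy position, such as a methyl ester or a primary amide, would give a higher, lower or level number, and whether a longer chain in place of the methoxymethyl would change the number. They also leave open whether methoxy and methoxymethyl would still read alike with the carboxy group present.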